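This account rests on a few compounds, and the source may have more. Where it says the series, first, only, none or still open, it means among the compounds named here.

Of the compounds shown here, three sharing one core have been measured in an in vitro ADME assay on microsomes from liver (Homo sapiens) for metabolic stability; on this read-out higher numbers stand for a longer-lived compound and lower numbers for a shorter-lived compound. Compound 1 `CC(=O)n1cc(C(=O)O)c(Nc2ccc(I)cc2F)c1C` gives 0.483 h. Compound 2 `CC(=O)c1cc(C(=O)NOCCCO)c(Nc2ccc(I)cc2F)n1C` gives 0.717 h, and compound 3 `CC(=O)c1cc(C(=O)NOC(CO)CO)c(Nc2ccc(I)cc2F)n1C` gives 1.5 h. Among these three numbers compound 2 stands second highest; compound 1 lies within the scatter of it, and the only step beyond the scatter is a 2.1-fold higher number from compound 2 to compound 3 (0.32 log units; beyond the scatter).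

The next compound, compound 4 `CC(=O)c1cc(C(=O)N2CC(N)C2)c(Nc2ccc(I)cc2F)n1C`, has not yet been measured. It differs from compound 2 in one place: 3-aminoazetidin-1-yl in place of (3-hydroxypropoxy)amino on a carbonyl carbon. Among the compounds with values here, no measured step bears on this exchange: the one step that exists swaps one chain for another on an oxygen, whereas here the whole (3-hydroxypropoxy)amino group gives way to a ring. There is thus nothing to say how large the step to compound 4 will be, or in which direction. The step from compound 2 is expected to be a 1.3-fold higher number from compound 2 to compound 4 (0.10 log units; within the scatter), a change within the scatter. Compound 4 is therefore estimated at 0.9 h, within a range from 0.4 h to 2 h.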

Compound 4, half-life: 0.917 h
Compound 4: middle estimate off by 1.0-fold (0.01 log units), on the low side; the measured number falls inside the stated range.
By their numbers in this assay, from the lowest: compounds 1, 2, 4 and 3 (each within the scatter of the next, the first and the last beyond it).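

In this assay, putting 3-aminoazetidin-1-yl on the carbonyl carbon in place of (3-hydroxypropoxy)amino gives a 1.3-fold higher number from compound 2 to compound 4 (0.11 log units; within the scatter), and the same group in place of (2-hydroxy-1-(hydroxymethyl)ethoxy)amino gives a 1.6-fold lower number from compound 3 to compound 4 (0.21 log units; within the scatter). The earlier step compared only two chains on an oxygen, whereas these show that a four-membered ring carrying an amine, with no oxygen in the group, can take the place of either open chain without a step beyond the scatter. Nothing available explains why so different a group leaves the number within the scatter.

The compounds shown leave open whether the ring or its amine matters more for this read-out. An azetidine carrying a hydroxyl in place of the amine, or a larger ring such as a pyrrolidine, would help to separate the two.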